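Replacing a Ring Carrier with a Hydroxyl-Bearing Branch

This account rests on a few compounds, and the source may have more. Where it says the series, first, only, none or still open, it means among the compounds named here.

Measured so far:
Compound 1, `CCCNC(=O)c1ccc(C#Cc2cccc(F)c2)cn1`: 65.9%
Compound 2, `O=C(NCC1CCC1)c1ccc(C#Cc2cccc(F)c2)cn1`: 68.1%

For the measured compounds named here, in a functional assay on HEK293 cells for positive allosteric modulation of metabotropic glutamate receptor 5 (Rattus norvegicus), read by fluorescence and calcium flux (a lower number here means a smaller maximal response, a higher number a larger maximal response), compound 2 gives 68.1%, and the one step leading to it, a number 2.2 percentage points higher from compound 1 to compound 2 (within the scatter), lies within the scatter, so compounds 1 and 2 share one level. Compound 3, `CC(C)(CO)NC(=O)c1ccc(C#Cc2cccc(F)c2)cn1`, differs from compound 2 as follows: 1-(hydroxymethyl)-1-methylethyl in place of cyclobutylmethyl on an amide-type nitrogen. Going by the values given here, only the step from compound 1 bears on this change, and it moved little; no measured compound carries a hydroxyl group, so the new group adds uncertainty. A step of a number 8.1 percentage points lower from compound 2 to compound 3 (within the scatter) is expected, modest and downward. For compound 3 the estimate is 60%, within 40% to 80%.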

Compound 3, largest response reached (reported as efficacy), in percent of the reference or control that the assay uses: 60.9%
For compound 3 the middle estimate is 0.9 percentage points below the measured one; low and high end bracket the measured number.
By their numbers in this assay, from the lowest: compounds 3, 1 and 2 (each within the scatter of the next).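

In this assay, putting 1-(hydroxymethyl)-1-methylethyl on the amide-type nitrogen gives a number 7.2 percentage points lower from compound 2 to compound 3 (within the scatter) and, against the propyl group, a number 5 percentage points lower from compound 1 to compound 3 (within the scatter), so all three compounds share one level. This place therefore accepts a branched group with a hydroxyl, which brings one hydrogen-bond donor and one acceptor, as well as a carbon-only chain or ring carrier. Nothing measured here explains this. The branching and the hydroxyl changed together, and a straight 2-hydroxyethyl group would help separate them. As far as these compounds go, whether an amine or a carboxylic acid at this place would hold the same level remains open.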